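Phenyl for Methylamino on the Sulfonyl of Compound 1

This account rests on a few compounds, and the source may have more. Where it says the series, first, only, none or still open, it means among the compounds named here.

Compound 1 `CNS(=O)(=O)c1ccc2c(c1)C(n1ccccc1=O)=CC(C)(C)O2`: in a functional assay on the whole organism (aorta) with Rattus norvegicus as the target (a lower number here means a smaller maximal response, a higher number a larger maximal response), compound 1 gives 85.8%
Compound 2 `CC(C)NS(=O)(=O)c1ccc2c(c1)C(n1ccccc1=O)=CC(C)(C)O2`: in this assay compound 2 gives 76.9%
Compound 3 `COc1ccc(NS(=O)(=O)c2ccc3c(c2)C(n2ccccc2=O)=CC(C)(C)O3)cc1`: in this assay compound 3 gives 77.9%

Compound 1 holds the highest of the three numbers, yet both of its neighbours stay within the scatter: a number 8.9 percentage points lower from compound 1 to compound 2 (within the scatter) and a number 7.9 percentage points lower from compound 1 to compound 3 (within the scatter), and between them a number 1 percentage points higher from compound 2 to compound 3 (within the scatter). So no compound here can be set apart from another.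

Compound 4 `CC1(C)C=C(n2ccccc2=O)c2cc(S(=O)(=O)c3ccccc3)ccc2O1` is the step from compound 1 in which (phenyl in place of methylamino on a sulfonyl sulfur). The two measured steps that touch the same sulfonyl group both swapped the substituent on the sulfonamide nitrogen and left the read-out unchanged beyond the scatter. For the measured compounds named here, the change to compound 4 goes one bond deeper, removing the nitrogen itself, and no measured step covers that exactly. On the evidence of compound 2 and compound 3, a step within the scatter is expected for this assay, leaning slightly lower as both of those did: a number 7.8 percentage points lower from compound 1 to compound 4 (within the scatter). Compound 4 is therefore estimated at 78%, with a range from 62% to 92%.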

Compound 4, largest response reached (Emax), in percent of the reference or control that the assay uses: 79.3%
For compound 4 the middle estimate is 1.3 percentage points below the measured one; the measured number falls inside the stated range.
By their numbers in this assay, from the lowest: compounds 2, 3, 4 and 1 (each within the scatter of the next).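

In this assay, taking out the sulfonamide nitrogen and placing phenyl directly on the sulfonyl sulfur gives a number 6.5 percentage points lower from compound 1 to compound 4 (within the scatter), so this deeper change, which also removes the hydrogen-bond donor of methylamino, does not separate the two compounds. Against the other two sulfonamides the outcome is the same, with a number 1.4 percentage points higher from compound 3 to compound 4 (within the scatter) and a number 2.4 percentage points higher from compound 2 to compound 4 (within the scatter), so a sulfonyl group without any nitrogen cannot be told apart from those with one. No independent measurement bears on why the response stays so flat here.

Going by these compounds, whether any group on this sulfonyl sulfur can move the maximal response beyond the scatter remains open, for instance an unsubstituted amine, a hydroxyl or a simple methyl. The compounds shown also leave open what a change elsewhere on the shared core would do.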